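Pyrrolidin-1-yl versus piperidin-1-yl on the thiocarbonyl carbon

The source may hold more compounds than are shown below. What is called first, only, known or untested is meant among the compounds shown, and "the series" means these compounds.

Measured so far:
compound 1 `Cc1ccc2c(=O)c(CSC(=S)N3CCCCC3)coc2c1` gives 800 nM
compound 2 `Cc1ccc2c(=O)c(CSC(=S)N3CCCC3)coc2c1` gives 41400 nM
compound 3 `CCOC(=O)c1cc(=O)c2cc(CSC(=S)N3CCCC3)ccc2o1` gives only the limit > 25000 nM

All three were tested in a functional assay on MCF7 cells (Homo sapiens) for antiproliferative activity, read by MTT assay, with a stated time of 72 h; on this read-out higher numbers stand for weaker inhibition and lower numbers for stronger inhibition. Within the core of compound 1 and compound 2, the one counted change is piperidin-1-yl in place of pyrrolidin-1-yl on a thiocarbonyl carbon, and it brought a 52-fold lower number from compound 2 to compound 1 (1.71 log units; beyond the scatter). The only further point of reference for this series is the limit of > 25000 nM in this assay, at which 1 of the 3 values shown sits; compound 3 sits at that limit, so its own value is not a number.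

Compound 3 carries a different core from compound 2; the difference between the two cores is not broken down here. The unmeasured compound 4 `CCOC(=O)c1cc(=O)c2cc(CSC(=S)N3CCCCC3)ccc2o1` differs from compound 3 by piperidin-1-yl in place of pyrrolidin-1-yl on a thiocarbonyl carbon. For the measured compounds named here, this is the same kind of change as the one between compound 2 and compound 1, and the place lines of the two changes match word for word.

For compound 4 the step from compound 3 is expected to be of the same sign as the one already seen, but its size cannot be set firmly, since the starting value of compound 3 is a limit rather than a number; the expected step is an at least 8.3-fold lower number from compound 3 to compound 4 (0.92 log units; beyond the scatter). On that basis compound 4 is estimated at 3000 nM in this assay, with a plausible span from 400 nM to 25000 nM, and a real chance that compound 4 is again reported only as a limit.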

Compound 4, half-maximal inhibitory concentration: 21900 nM
Compound 4: middle estimate off by 7.3-fold (0.86 log units), on the low side; measured number inside the range.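

Carried to the core of compound 3, piperidin-1-yl in place of pyrrolidin-1-yl on a thiocarbonyl carbon gives an at least 1.1-fold lower number from compound 3 to compound 4 (0.05 log units; that floor lies within the scatter) in this assay, and the comparison with the earlier step goes only this far: the same change on two cores in this assay, a 52-fold lower number (1.71 log units; beyond the scatter) from compound 2 to compound 1 and an at least 1.1-fold lower number (0.05 log units; that floor lies within the scatter) from compound 3 to compound 4; the limit leaves it open whether they differ. Compound 3 stands at a limit, > 25000 nM, and not at a number, so the new step has a floor but no measured size: the limit of > 25000 nM in this assay, at which 1 of the 4 values shown sits. The change is therefore neither shown to carry over to the second core nor shown to fail there, since a step as large as the earlier one and a step within the scatter both remain possible.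

The compounds shown leave open whether the large step belongs only to the core of compound 1 and compound 2 or would also appear on the core of compound 3 if that core's pyrrolidin-1-yl compound could be read as a number. Also open, on these data alone, is how morpholin-4-yl or an open-chain diethylamino group on the thiocarbonyl carbon would read in this assay, and whether a carboxylic acid in place of the ethyl ester of compound 4 would alter the picture.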